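Notes on the step to compound 4

The source may hold more compounds than are shown below. What is called first, only, known or untested is meant among the compounds shown, and "the series" means these compounds.

Values measured in a functional assay on HT-29 cells (Homo sapiens) for antiproliferative activity, read by sulforhodamine B assay, with a stated time of 48 h (a higher number here means a weaker inhibitor, a lower number a stronger inhibitor), follow.
- compound 1 `CCN1CCN(c2ccc(S(=O)(=O)Oc3ccccc3OC)cc2)C1=O` gives > 100000 nM (a limit)
- compound 2 `CCN1CCN(c2ccc(S(=O)(=O)Oc3cccc(Br)c3)cc2)C1=O` gives 3800 nM
- compound 3 `CCCCN1CCN(c2ccc(S(=O)(=O)Oc3ccccc3)cc2)C1=O` gives > 100000 nM (a limit)

Compound 3 stands at > 100000 nM, which is a limit and not a number. Compound 4 `CCCCN1CCN(c2ccc(S(=O)(=O)Oc3ccc(OC)c(OC)c3)cc2)C1=O` differs from it as follows: 3,4-dimethoxyphenyl in place of phenyl on an oxygen. Among the compounds with values here, the only measured step at this place is an at least 26-fold lower number from compound 1 to compound 2 (1.42 log units; beyond the scatter). It is large, but it was measured with an ethyl chain and with other groups, so it gives only a rough guide. A lower number is therefore expected in this assay, possibly by a large step, although a further limit remains possible. The estimate implies an expected at least 12-fold lower number from compound 3 to compound 4 (1.09 log units; beyond the scatter). Compound 4 is expected at 8000 nM, with an estimated range of 800 nM to 100000 nM.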

Compound 4, half-maximal inhibitory concentration: 21000 nM
Compound 4: middle estimate off by 2.6-fold (0.42 log units), on the low side; the range from low to high includes it.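

With the butyl chain held fixed, 3,4-dimethoxyphenyl in place of phenyl on the oxygen bound to the sulfonyl sulfur gives an at least 4.7-fold lower number from compound 3 to compound 4 (0.67 log units; beyond the scatter) in this assay. The group at this place therefore changes the read-out with the butyl chain as well, whereas the earlier step carried the ethyl chain. The true size of this step stays unread, and only its lower bound is known: the limit of > 100000 nM in this assay, at which 2 of the 4 values shown sit.

Open, going by these compounds, is whether one methoxy group alone would give the same change. Also open, on these data alone, is how a carboxylic acid or an amine on this ring would read.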